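From 3-chloro-4-fluorophenyl to 3-nitrophenyl

This account rests on a few compounds, and the source may have more. Where it says the series, first, only, none or still open, it means among the compounds named here.

Compound 1 `C/C(=C\CC/C(C)=C/CC[C@@H]1[C@@]2(C)CCC(=O)C(C)(C)[C@H]2CC[C@@]1(C)O)CC/C=C(\C)C(=O)OCc1cn(-c2ccc(F)c(Cl)c2)nn1` gives 22900 nM
Compound 2 `C/C(=C\CC/C(C)=C/CC[C@@H]1[C@@]2(C)CCC(=O)C(C)(C)[C@H]2CC[C@@]1(C)O)CC/C=C(\C)C(=O)OCc1cn(C[C@@H]2O[C@H](n3ccc(=O)[nH]c3=O)C[C@H]2O)nn1` gives 10900 nM

Both values come from a functional assay on PC-3 cells (Homo sapiens) for antiproliferative activity, read by MTT assay, with a stated time of 48 h; on this read-out higher numbers stand for weaker inhibition and lower numbers for stronger inhibition. Compound 1 has the higher number of the two, which makes it the weaker inhibitor here, and the gap to compound 2 lies just beyond the usual scatter.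

Compound 3 `C/C(=C\CC/C(C)=C/CC[C@@H]1[C@@]2(C)CCC(=O)C(C)(C)[C@H]2CC[C@@]1(C)O)CC/C=C(\C)C(=O)OCc1cn(-c2cccc([N+](=O)[O-])c2)nn1` keeps the core of compound 1 and changes one group: 3-nitrophenyl in place of 3-chloro-4-fluorophenyl on an aromatic nitrogen. In words, 3-nitrophenyl stands in place of 3-chloro-4-fluorophenyl on an aromatic nitrogen. For the measured compounds named here, no measured pair shows this exact change, so the data offer only an indirect guide. Compound 2 carries a quite different group on that nitrogen, and compound 2 gives 10900 nM while compound 1 gives 22900 nM. A small step in this assay is therefore expected, with no clear direction and most likely none beyond the scatter. The expected change is a 1.1-fold lower number from compound 1 to compound 3 (0.06 log units; within the scatter). For compound 3 the estimated value is 20000 nM, with an expected range from 9000 nM to 45000 nM.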

Compound 3, half-maximal inhibitory concentration: 24800 nM
Estimate against measurement, compound 3: 1.2-fold (0.09 log units) below, within the range that was stated.
By their numbers in this assay, from the lowest: compound 2; then compounds 1 and 3 (each within the scatter of the next).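

In this assay, placing 3-nitrophenyl where 3-chloro-4-fluorophenyl stood on the aromatic nitrogen gives a 1.1-fold higher number from compound 1 to compound 3 (0.03 log units; within the scatter), so this read-out does not separate the two compounds. For the compounds shown here, this is the first pair in which the group on that nitrogen changes while its six-membered aromatic ring of carbon stays, and it shows that replacing the chlorine and fluorine with a nitro group, which adds the hydrogen-bond acceptors counted for 3-nitrophenyl, leaves no visible mark on the result. Nothing available here explains why this exchange makes no measurable difference.

As far as these compounds go, it remains open whether a phenyl ring carrying an amine or a carboxylic acid on the same nitrogen would stay level with compound 1 and compound 3, and the same goes for an unsubstituted phenyl ring or a longer alkyl chain. Compound 2, with its quite different group on that nitrogen, gives 10900 nM, and the compounds shown do not tell which part of that group goes with this number.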